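The source may hold more compounds than are shown below. What is called first, only, known or untested is meant among the compounds shown, and "the series" means these compounds.

Measured compounds:
compound 1, `COc1cc(Cl)cc(-c2nn(-c3cccc(NC(=O)c4ccc(Cl)c(Cl)c4)c3)cc2-c2ccncc2)c1`: 43.6%
compound 2, `O=C(Nc1cccc(-n2cc(-c3ccncc3)c(-c3cc(O)cc(Cl)c3)n2)c1)Nc1ccc(Cl)c(C(F)(F)F)c1`: -30.6%

In a functional assay on SR cells (Homo sapiens) for inhibition, read by sulforhodamine B assay, with a stated time of 48 h, tested at 10 uM (on this read-out lower numbers stand for a stronger effect and higher numbers for a weaker effect at the one concentration tested), compound 1 gives 43.6%, and in this assay compound 2 gives -30.6%. Compound 2 therefore stands at the lower of the two numbers, and its gap to compound 1 lies beyond the usual scatter. Going by the values given here, no step between these two compounds is recorded, as they differ in several places at once, so nothing more than the two values themselves can be said of the pair.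

Compound 3, `O=C(Nc1cccc(-n2cc(-c3ccncc3)c(-c3cc(O)cc(Cl)c3)n2)c1)Nc1ccc(Cl)c(Cl)c1`, has not yet been measured. It differs from compound 2 in a single place: chloro in place of trifluoromethyl on an aromatic carbon. Among the compounds with values here, no step of this kind between measured compounds is available, so the expectation rests on the change itself being small, as the counted difference shows. The step from compound 2 to compound 3 in this assay is expected to be a number 5.6 percentage points higher from compound 2 to compound 3 (within the scatter), not beyond the scatter. Compound 3 is estimated at -25% in this assay. Its lower end is expected near -55%. Its upper end is expected near 5%.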

Compound 3, a percentage reported as activity, at one concentration (the size of the read-out at that concentration, not a potency): -21.4%
The estimate for compound 3 lay 3.6 percentage points below the measured number; measured number inside the range.
By their numbers in this assay, from the lowest: compounds 2 and 3 (each within the scatter of the next); then compound 1.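

In this assay, going by these compounds alone, the exchange of trifluoromethyl for chloro, on an aromatic carbon ortho to a chloro group and meta to a large group, gives a number 9.2 percentage points higher from compound 2 to compound 3 (within the scatter) and is the first single-place step available in this set. It shows that a 3,4-dichlorophenyl can stand in place of a 4-chloro-3-(trifluoromethyl)phenyl on this urea without a step beyond the scatter, even though four heavy atoms leave and only one enters, and compound 3 still gives a negative number at -21.4% in this read-out. No measurement shown here offers a reason for this result.

As far as these compounds go, whether this position would accept groups other than these two, such as a nitrile, a methoxy or an amine, remains open, as does whether removing the group altogether would leave the read-out where it stands. Within the data shown here, the separate contributions of the urea, the amide and the hydroxy and methoxy groups to the gap between compound 1 and the other two compounds also remain open, since no single-place step connects them.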